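This account rests on a few compounds, and the source may have more. Where it says the series, first, only, none or still open, it means among the compounds named here.

Working notes on the series

Compound 1 `COc1ncnc2c1c(-c1ccsc1)cn2[C@@H]1O[C@H](CO)[C@@H](O)[C@H]1O` is the reference point. In a functional assay on K562 cells (Homo sapiens), read by MTT assay, with a stated time of 72 h (a lower number here means a stronger inhibitor, a higher number a weaker inhibitor), compound 1 gives 3450 nM. Compound 2 `COc1nc(N)nc2c1c(-c1ccsc1)cn2[C@@H]1O[C@H](CO)[C@@H](O)[C@H]1O` carries the change (amino in place of hydrogen on an aromatic carbon). Compound 2 reaches only a limit of the assay, > 20000 nM. The step of an at least 5.7-fold higher number from compound 1 to compound 2 (0.76 log units; beyond the scatter) is therefore at least modest in size, and its true extent is open, since the value sits at the limit of > 20000 nM in this assay, at which 1 of the 3 values shown sits.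

Compound 3 `O=c1[nH]cnc2c1c(-c1ccco1)cn2[C@@H]1O[C@H](CO)[C@@H](O)[C@H]1O` has a different core; the difference between the two cores is not broken down here. In this assay compound 3 gives 17800 nM, the highest of the two numbers shown, compound 1 standing lower.

Compound 4 `Nc1nc2c(c(-c3ccco3)cn2[C@@H]2O[C@H](CO)[C@@H](O)[C@H]2O)c(=O)[nH]1` is not yet measured. It differs from compound 3 by amino in place of hydrogen on an aromatic carbon. For the measured compounds named here, this is the same kind of change as the one from compound 1 to compound 2, though the surroundings differ: in compound 4 the position is meta to a group of 1 heavy atom, whereas in compound 2 it is meta to a methoxy group (2 heavy atoms). Because an at least 5.7-fold higher number from compound 1 to compound 2 (0.76 log units; beyond the scatter) went beyond the scatter, compound 4 is expected to move by a 2.8-fold higher number from compound 3 to compound 4 (0.45 log units; beyond the scatter). Starting from the weak compound 3, compound 4 is estimated at 50000 nM, with a likely range of 15000 nM to 200000 nM.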

Compound 4, half-maximal inhibitory concentration: > 20000 nM
Compound 4: only a limit was reported; the forecaster's own chance of this, stated with the estimate: 75%; the middle value lies beyond the limit too.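

In this assay compound 4 reaches only a limit of the assay, > 20000 nM. Read as a floor, the change gives an at least 1.1-fold higher number from compound 3 to compound 4 (0.05 log units; that floor lies within the scatter), so amino in place of hydrogen on an aromatic carbon shows no lower number on either core, but the true size of the step on the core of compound 3 stays unknown and the two steps cannot be ranked: the same change on two cores in this assay, an at least 5.7-fold higher number (0.76 log units; beyond the scatter) from compound 1 to compound 2 and an at least 1.1-fold higher number (0.05 log units; that floor lies within the scatter) from compound 3 to compound 4; the limit leaves it open whether they differ. Compound 2 and compound 4 both stop at the same limit, so the series shows the direction of this change at best, not how far it carries from one core to another: the limit of > 20000 nM in this assay, at which 2 of the 4 values shown sit.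

Still open, on these data alone, is whether amino has the same size of effect on the two cores, which would take values for both amino compounds that fall inside the range of the assay. Also open, as far as these compounds go, is how a group other than amino, such as methyl or chlorine, would read on this aromatic carbon between two ring nitrogen atoms.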